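A few compounds are considered here, and "the series" means these few. Any claim that something is new, unique, unknown or untested is made for them only; others in the source may bear on it.

Working notes on the series.

Compound 1 `O=C(NC(=S)NNc1ncnc2ccccc12)c1ccccc1F` gives 2510 nM in a functional assay on KB cells (Homo sapiens) for cytotoxicity, read by MTT assay, with a stated time of 72 h; on this read-out lower numbers stand for stronger inhibition and higher numbers for weaker inhibition. Among the three numbers so far it stands lowest. Compound 2 `COc1cc2ncnc(NNC(=S)NC(=O)c3ccc(F)cc3)c2cc1OC` gives 4530 nM in this assay, and this sits within the scatter of compound 1. Compound 3 `COc1cc2ncnc(NNC(=S)NC(=O)c3ccc(C)cc3)c2cc1OC` gives 24200 nM in this assay, clearly apart from compound 1.

Compound 4 `O=C(NC(=S)NNc1ncnc2ccccc12)c1cccc(Cl)c1` is the next candidate. Against compound 1 the change is 3-chlorophenyl in place of 2-fluorophenyl on a carbonyl carbon.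

Going by the values given here, only one measured step touches the aryl amide end: a 5.3-fold higher number from compound 2 to compound 3 (0.73 log units; beyond the scatter). It shows that a change of the single substituent on that ring can move the read-out beyond the scatter, but it is a methyl-for-fluoro exchange on the dimethoxy core, not a chloro-for-fluoro exchange with a shift of position on the unsubstituted core of compound 1. Among the compounds with values here, no pair in the set varies the position of the substituent alone, and no pair trades one halogen for another.

The change from compound 1 to compound 4 is therefore expected to give at most a small weakening in this assay, with the direction uncertain, as a 1.4-fold higher number from compound 1 to compound 4 (0.14 log units; within the scatter). For compound 4 the expected value in this assay is 3500 nM, with a range from 1200 nM to 10000 nM.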

Compound 4, half-maximal inhibitory concentration: 4740 nM
Compound 4: the middle estimate sits 1.4-fold (0.13 log units) below what was measured; the measured number falls inside the stated range.
By their numbers in this assay, from the lowest: compounds 1, 2 and 4 (each within the scatter of the next); then compound 3.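

In this assay, 3-chlorophenyl in place of 2-fluorophenyl on a carbonyl carbon gives a 1.9-fold higher number from compound 1 to compound 4 (0.28 log units; within the scatter), so on this core a change in both the halogen and its place on the ring leaves the read-out within the scatter. Set beside a 5.3-fold higher number from compound 2 to compound 3 (0.73 log units; beyond the scatter), which lies beyond the scatter on a different core, this shows that not every change of the single substituent on this ring moves the read-out, although the two steps differ in both core and groups and cannot be ranked as like for like. No supporting measurement accompanies these results that could account for the size of either step.

The halogen and its place change together in the new step, so the compounds shown cannot separate the two, and a small step here may also hide opposing contributions. Also open, going by these compounds, is whether an amine or a carboxylic acid on the phenyl ring, or a longer chain in its stead on the carbonyl carbon, would likewise stay within the scatter of compound 1.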